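A few compounds are considered here, and "the series" means these few. Any claim that something is new, unique, unknown or untested is made for them only; others in the source may bear on it.

Measured compounds:
- compound 1, `CC(C)(C)c1ccc(C(=O)N2CCC3(CC2)C(=O)N(CC(=O)NCCO)CN3c2ccccc2)cc1`: 1000 nM
- compound 2, `CC(C)(C)c1ccc(C(=O)N2CCC3(CC2)C(=O)N(CC(=O)NCCN)CN3c2ccccc2)cc1`: 7000 nM

Going by the values given here, in an assay on HEK293 cells for displacement of a labelled ligand from NPC1-like intracellular cholesterol transporter 1 (Homo sapiens) (on this read-out lower numbers stand for stronger inhibition and higher numbers for weaker inhibition), compound 1 gives the lowest of the two numbers; its nearest neighbour is compound 2, where a 7.0-fold higher number from compound 1 to compound 2 (0.85 log units; beyond the scatter) is the only measured step, and it concerns the chain on the amide-type nitrogen, not the aromatic substituent.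

Compound 3, `O=C(CN1CN(c2ccccc2)C2(CCN(C(=O)c3ccc(C4CCCCC4)cc3)CC2)C1=O)NCCO`, is not yet measured. It differs from compound 1 by cyclohexyl in place of tert-butyl on an aromatic carbon, at the para position of the benzoyl ring. Among the compounds with values here, no measured pair in this set changes that group, so the one known step gives no direct guide to the size or direction of the change. Lacking such a precedent, the working expectation is a step no larger than the scatter, with the number for compound 3 estimated near that of compound 1: no change at the digits printed from compound 1 to compound 3 (within the scatter), giving an estimated 1000 nM with a range from 300 nM to 3500 nM.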

Compound 3, half-maximal inhibitory concentration: 2000 nM
The estimate for compound 3 lay 2.0-fold (0.30 log units) below the measured number; the range from low to high includes it.
By their numbers in this assay, from the lowest: compounds 1 and 3 (each within the scatter of the next); then compound 2.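

In this assay cyclohexyl in place of tert-butyl on an aromatic carbon gives a 2.0-fold higher number from compound 1 to compound 3 (0.30 log units; within the scatter) and so shows that this position takes a change from 4 to 6 heavy atoms, with one six-membered non-aromatic ring of carbon only, without a step beyond the scatter. The earlier step on the chain, a 7.0-fold higher number from compound 1 to compound 2 (0.85 log units; beyond the scatter), does lie beyond the scatter, whereas this change at the aromatic carbon does not separate its two compounds. Nothing available accounts for this result.

From the compounds shown here alone, whether a phenyl ring, a methyl group or a hydrogen at this carbon would stay within the scatter of compound 1 remains open. Also open, going by these compounds, is whether cyclohexyl would give a similar step when paired with the amino-ended chain of compound 2.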